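The source may hold more compounds than are shown below. What is called first, only, known or untested is meant among the compounds shown, and "the series" means these compounds.

Measured compounds so far:
Compound 1 `COc1ccc(Cl)cc1C(=O)Nc1ccc(C2=NN(c3ccccc3)C(c3ccccc3[N+](=O)[O-])C2)cc1` — in a functional assay on the whole organism (plasma, strain albino) for inhibition, with Rattus norvegicus as the target, with stated times of 1 h and 4 h, at a dose of 25 mg/kg by the oral route (a lower number here means a weaker effect, a higher number a stronger effect of the compound at the dose given), compound 1 gives 73.3%.
Compound 2 `COc1ccc(C2CC(c3ccc(NC(=O)c4cc(Cl)ccc4OC)cc3)=NN2)cc1` — in this assay compound 2 gives 70.6%.

Going by the values given here, only two compounds have numbers, and they lie within the usual scatter of each other, so neither can be called the stronger or the weaker; compound 2 and compound 1 behave alike at the dose given. Among the compounds with values here, compound 1 also carries a phenyl on a ring nitrogen of the shared core, which compound 2 does not, so no single-change step between measured compounds exists here.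

The next compound, compound 3 `COc1ccc(Cl)cc1C(=O)Nc1ccc(C2=NNC(c3ccccc3[N+](=O)[O-])C2)cc1`, is made from compound 2 by one change: 2-nitrophenyl in place of 4-methoxyphenyl on a saturated ring carbon. The group that enters is the same one that compound 1 carries at that place, and compound 1 and compound 2 give numbers within the scatter of each other, so nothing in the data points to a step beyond the scatter in either direction.

For compound 3 the expected step in this assay is a number 0.4 percentage points higher from compound 2 to compound 3 (within the scatter), which is none beyond the scatter. Compound 3 is therefore estimated at 71%, with a range from 60% to 82%.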

Compound 3, a percentage reported as inhibition, in the whole organism at one dose (the size of the read-out at that dose, not a potency): 72.3%
Compound 3: middle estimate off by 1.3 percentage points, on the low side; low and high end bracket the measured number.
By their numbers in this assay, from the lowest: compounds 2, 3 and 1 (each within the scatter of the next).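

With 2-nitrophenyl in place of 4-methoxyphenyl on the saturated ring carbon, this assay shows a number 1.7 percentage points higher from compound 2 to compound 3 (within the scatter) and so, for these two groups, the position gives no measurable preference at the dose given. The phenyl on the ring nitrogen can now also be judged on its own, a comparison that the first two compounds did not allow: hydrogen in its place gives a number 1 percentage points lower from compound 1 to compound 3 (within the scatter) and so, with 2-nitrophenyl on the saturated ring carbon, that phenyl is not needed to keep the effect seen at this dose. Nothing measured here accounts for how little these two changes move the number.

On these data alone, all three compounds carry a substituted phenyl ring on the saturated ring carbon, so it remains open whether the effect holds with something quite different there, such as a methyl, an amine or a carboxylic acid. A read-out at a single dose also gives only the size of the effect at that dose, so these compounds could still give a stronger or weaker effect than one another at other doses, even though their numbers at this dose lie within the scatter of each other.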